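Dropping the Acetamido: From Compound 3 to Compound 4

The source may hold more compounds than are shown below. What is called first, only, known or untested is meant among the compounds shown, and "the series" means these compounds.

Measured compounds:
compound 1 `CC1CCN(C2CCN(S(=O)(=O)c3ccc(OCc4ccccc4)cc3)CC2)CC1` — 385 nM
compound 2 `CC1CCN(C2CCN(S(=O)(=O)c3ccc(C(C)C)cc3)CC2)CC1` — 685 nM
compound 3 `CC(=O)Nc1ccc(S(=O)(=O)N2CCC(N3CCC(C)CC3)CC2)c2ccccc12` — 1100 nM

All three share the same core and were tested in a functional assay on DLD-1 cells (Homo sapiens) for antiproliferative activity, read by CellTiter-Glo, with a stated time of 72 h (a higher number here means a weaker inhibitor, a lower number a stronger inhibitor), where compound 3 gives 1100 nM, the highest number of the three. Its gap to compound 2 is within the scatter, so the two cannot be ranked; its gap to compound 1 is beyond the scatter, so compound 1 is the stronger of that pair.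

Compound 4 `CC1CCN(C2CCN(S(=O)(=O)c3cccc4ccccc34)CC2)CC1` differs from compound 3 in one place: hydrogen in place of acetamido on an aromatic carbon. Going by the values given here, the only measured step, a 1.8-fold higher number from compound 1 to compound 2 (0.25 log units; within the scatter), swaps one group for another on a different aromatic ring; no measured pair removes a group altogether, so it bears on this change only loosely, and it shows that such swaps stay small. A step of modest size in either direction, possibly none beyond the scatter, is expected in this assay . Compound 4 is therefore estimated at 800 nM, with a range from 300 nM to 2500 nM. This estimate means an expected step of a 1.4-fold lower number from compound 3 to compound 4 (0.14 log units; within the scatter).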

Compound 4, half-maximal inhibitory concentration: 0.65 nM
Compound 4: the middle estimate sits 1200-fold (3.09 log units) above what was measured; measured number below the stated range.
By their numbers in this assay, from the lowest: compound 4; then compounds 1, 2 and 3 (each within the scatter of the next, the first and the last beyond it).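

On this aromatic carbon, para to a large group, the choice between acetamido and hydrogen decides most of the activity in this assay: a 1700-fold lower number from compound 3 to compound 4 (3.23 log units; beyond the scatter). The earlier step, a 1.8-fold higher number from compound 1 to compound 2 (0.25 log units; within the scatter), stayed within the scatter, so the first three compounds gave no sign that a single change on this series could matter so much. Nothing available here explains the size of this step.

From the compounds shown here alone, what remains open is whether any group on this carbon costs activity or acetamido is a special case, and a group such as methyl, an amine or a hydroxyl at the same place would help separate the two. Whether such a compound could come close to compound 4 at 0.65 nM cannot be told from these compounds.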